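Tetrazole chain length at the carbonyl carbon: compound 4

The compounds below may be only part of what the source reports. "The series", "measured", "known", "first", "only" and "open" are said of these compounds alone.

Measured so far:
compound 1 `CCCc1c(COc2ccc(C(=O)CCC(=O)O)cc2)ccc(C(C)=O)c1O` — 6.75
compound 2 `CCCc1c(COc2ccc(C(=O)C(C)Cc3nnn[nH]3)cc2)ccc(C(C)=O)c1O` — 7.18
compound 3 `CCc1c(COc2ccc(C(=O)CC(C)(C)Cc3nnn[nH]3)cc2)ccc(C(C)=O)c1O` — 8.09

All three were run in a functional assay on ileum (Cavia porcellus) with cysteinyl leukotriene receptor (Homo sapiens) as the target; a higher number here means a more potent compound, by a factor of ten per unit of this negative logarithm, a lower number a less potent compound. Compound 2 stands second highest of the three numbers; its nearest neighbour is compound 1, lower beyond the scatter, and its furthest is compound 3, higher beyond the scatter. Compound 2 and compound 3 differ in more than one place, so their values are only compared, not read as a step.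

Compound 4 `CCCc1c(COc2ccc(C(=O)CCCCCCc3nnn[nH]3)cc2)ccc(C(C)=O)c1O` is not yet measured. It differs from compound 2 in one place: 6-(1H-tetrazol-5-yl)hexyl in place of 1-((1H-tetrazol-5-yl)methyl)ethyl on a carbonyl carbon. Within the data shown here, the one measured step that bears on this position is a number 0.43 log units higher from compound 1 to compound 2 (beyond the scatter), where the tetrazole-bearing chain replaced a carboxylic acid chain. Among the measured compounds shown here, compound 4 keeps the tetrazole and only lengthens the chain, a change for which no measured pair exists; the higher value of compound 3 carries another difference as well. A step within the scatter, or a small rise, is expected: a number 0.12 log units higher from compound 2 to compound 4 (within the scatter). For compound 4 in this assay the estimate is 7.3, between 6.5 and 8.1.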

Compound 4, negative logarithm of the antagonist equilibrium constant: 7.33
The estimate for compound 4 lay 0.03 log units below the measured number; the range from low to high includes it.
By their numbers in this assay, from the lowest: compound 1; then compounds 2 and 4 (each within the scatter of the next); then compound 3.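

In this assay, 6-(1H-tetrazol-5-yl)hexyl in place of 1-((1H-tetrazol-5-yl)methyl)ethyl on the carbonyl carbon gives a number 0.15 log units higher from compound 2 to compound 4 (within the scatter), so compound 2 and compound 4 cannot be told apart and this position accepts the larger chain of 11 heavy atoms. Against the carboxylic acid chain, the step is a number 0.58 log units higher from compound 1 to compound 4 (beyond the scatter), so a second tetrazole chain, of a different size from that of compound 2, also stands above compound 1. Nothing at hand explains why the two tetrazole chains read alike.

Still open, from the compounds shown here alone, is whether a carboxylic acid at the end of the same hexyl chain would match the tetrazole. Also open, going by these compounds, is how a shorter butyl link, or an ether oxygen within the chain, would read at this position.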